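Emax notes: carbamate to amide at the piperidine carbonyl

The source may hold more compounds than are shown below. What is called first, only, known or untested is meant among the compounds shown, and "the series" means these compounds.

Measured so far in a functional assay on isolated protein for agonist activity at Glucose-dependent insulinotropic receptor (Rattus norvegicus), read by HTRF and cAMP accumulation; on this read-out higher numbers stand for larger maximal responses and lower numbers for smaller maximal responses:
- compound 1, `CC(C)S(=O)(=O)c1cnc(O[C@H]2CC[C@H](OC3CCN(C(=O)OC(C)(C)C)CC3)CC2)cn1`: 128%
- compound 2, `C[C@H](CF)OC(=O)N1CCC(O[C@H]2CC[C@H](Oc3cnc(S(C)(=O)=O)cn3)CC2)CC1`: 115%
- compound 3, `C[C@@H](CF)OC(=O)N1CCC(O[C@H]2CC[C@H](Oc3cnc(S(C)(=O)=O)cn3)CC2)CC1`: 123%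

Compound 3 stands second highest of the three numbers; its nearest neighbour is compound 1 and its furthest is compound 2, and both gaps lie within the usual scatter, so the three values cannot be ordered with confidence.

Going by the values given here, the only measured step is a number 8 percentage points higher from compound 2 to compound 3 (within the scatter), which rests on (the fact that compounds 2 and 3 differ only in the configuration as drawn). It concerns configuration alone and does not touch the carbonyl.

Compound 4, `CS(=O)(=O)c1cnc(O[C@H]2CC[C@H](OC3CCN(C(=O)C4(C(F)(F)F)CC4)CC3)CC2)cn1`, is not yet measured. Against compound 3 the change is a group of 7 heavy atoms (4 carbon, 3 fluorine; one three-membered non-aromatic ring of carbon only) in place of a group of 5 heavy atoms (3 carbon, 1 oxygen, 1 fluorine; no ring), on a carbonyl carbon. Among the compounds with values here, no measured step alters this part of the molecule, so nothing bears directly on it; the one step that exists was within the scatter, and the three values as a whole sit close together.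

On that basis the step of a number 3 percentage points lower from compound 3 to compound 4 (within the scatter) is expected to stay within the scatter. Compound 4 is therefore estimated at 120%, with a likely range from 105% to 135%.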

Compound 4, largest response reached (Emax), in percent of the reference or control that the assay uses: 140%
Estimate against measurement, compound 4: 20 percentage points below, outside the stated range (above it).
By their numbers in this assay, from the lowest: compounds 2, 3 and 1 (each within the scatter of the next, the first and the last beyond it); then compound 4.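

In this assay, 1-(trifluoromethyl)cyclopropyl on the carbonyl carbon, in place of the group of 5 heavy atoms, gives a number 17 percentage points higher from compound 3 to compound 4 (beyond the scatter) and a number 25 percentage points higher from compound 2 to compound 4 (beyond the scatter), so the gain holds against both drawn configurations of the group that leaves. This position can therefore move the maximal response beyond the scatter, which the configuration change alone did not show: a number 8 percentage points higher from compound 2 to compound 3 (within the scatter). Nothing available explains the gain.

The change removes the oxygen-containing group and brings in both the cyclopropyl ring and the trifluoromethyl at once, so the contribution of each part remains unresolved. Also open, as far as these compounds go, is whether a plain cyclopropyl or a 1-methylcyclopropyl on the same carbonyl carbon would keep the response of compound 4.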